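Amide Substituent Variation in a Paw Edema Series

The source may hold more compounds than are shown below. What is called first, only, known or untested is meant among the compounds shown, and "the series" means these compounds.

Measured compounds:
Compound 1, `CCN(CC)C(=O)CC1CCc2cc(OC)c(OC)cc21`: 40%
Compound 2, `CCCCCNC(=O)CC1CCc2cc(OC)c(OC)cc21`: 34%
Compound 3, `COc1cc2c(cc1OC)C(CC(=O)NC1CCCC1)CC2`: 52%

All three share one core and differ only in the group on the amide-type nitrogen. In a functional assay on the whole organism (strain Wistar) for inhibition, with Rattus norvegicus as the target, read by paw edema, with stated times of 60 min and 2 h, at a dose of 100 mg/kg by the oral route (a higher number here means more inhibition at the dose given (going by the name of the read-out), a lower number less inhibition), compound 1 gives 40%, compound 2 gives 34% and compound 3 gives 52%. Compound 3 stands highest of the three values: a number 12 percentage points higher from compound 1 to compound 3 (beyond the scatter) and a number 18 percentage points higher from compound 2 to compound 3 (beyond the scatter), both beyond the scatter, whereas a number 6 percentage points lower from compound 1 to compound 2 (within the scatter) lies within it.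

Compound 4, `COc1cc2c(cc1OC)C(CC(=O)NCc1ccccc1)CC2`, has not yet been measured in this assay. Its difference from compound 3 is benzyl in place of cyclopentyl on an amide-type nitrogen. Going by the values given here, two measured steps bear on this change, both at the same nitrogen: a number 18 percentage points higher from compound 2 to compound 3 (beyond the scatter) and a number 12 percentage points higher from compound 1 to compound 3 (beyond the scatter). Among the compounds with values here, both were modest gains ending at compound 3, so the cyclopentyl group goes with the highest number seen, while no measured compound carries an aromatic ring on that nitrogen. The swap of a five-membered ring for a benzyl group is therefore expected to move the number only modestly, if at all, and more likely downward than upward.

For compound 4 a value of 45% is expected, between 25% and 62%. This corresponds to an expected step of a number 7 percentage points lower from compound 3 to compound 4 (within the scatter), which may not clear the scatter.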

Compound 4, a percentage reported as inhibition, in the whole organism at one dose (the size of the read-out at that dose, not a potency): 24%
For compound 4 the middle estimate is 21 percentage points above the measured one; measured number outside the range, below it.
By their numbers in this assay, from the lowest: compounds 4, 2 and 1 (each within the scatter of the next, the first and the last beyond it); then compound 3.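

Compound 4 shows that a ring on the amide-type nitrogen does not by itself go with the higher number in this assay: benzyl also brings a ring, yet the change from cyclopentyl gives a number 28 percentage points lower from compound 3 to compound 4 (beyond the scatter). Set against the open-chain amides, the benzyl amide gives a split picture, with a number 10 percentage points lower from compound 2 to compound 4 (within the scatter) but a number 16 percentage points lower from compound 1 to compound 4 (beyond the scatter), so it cannot be told apart from the pentyl amide while it falls short of the diethyl amide. Among these four compounds the high number therefore belongs to the cyclopentyl group alone, and nothing at hand accounts for the difference between the saturated ring and the benzyl group.

As far as these compounds go, it remains open whether the higher number extends to other saturated rings on this nitrogen, such as cyclohexyl or cyclobutyl, or whether it is particular to cyclopentyl. From the compounds shown here alone, it is equally open whether phenyl bound directly to the nitrogen or a longer phenethyl group would stay with benzyl or move towards cyclopentyl, and all these numbers, read at a single dose, leave the ranking at other doses unsettled.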